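The compounds below may be only part of what the source reports. "The series", "measured", "known", "first", "only" and "open" are said of these compounds alone.

Measured so far:
compound 1 `O=C(Nc1c(C(O)(C(F)(F)F)C(F)(F)F)ccc2ccccc12)c1cccc(C(F)(F)F)c1` — 84 nM
compound 2 `COc1cccc(C(=O)Nc2c(C(O)(C(F)(F)F)C(F)(F)F)ccc3ccccc23)c1` — 185 nM
compound 3 `O=C(Nc1c(C(O)(C(F)(F)F)C(F)(F)F)ccc2ccccc12)c1ccc(Cl)cc1` — 570 nM

In an assay on LtK cells with ATP-sensitive inward rectifier potassium channel 11 (Homo sapiens) as the target (a higher number here means that more compound is needed for the effect, a lower number that less compound is needed), compound 3 gives the highest of the three numbers: the step from compound 2 is a 3.1-fold higher number from compound 2 to compound 3 (0.49 log units; beyond the scatter), and that from compound 1 is a 6.8-fold higher number from compound 1 to compound 3 (0.83 log units; beyond the scatter), both beyond the scatter. Compound 4 `O=C(Nc1c(C(O)(C(F)(F)F)C(F)(F)F)ccc2ccccc12)c1cnco1` is not yet measured. It differs from compound 3 in one place: 1,3-oxazol-5-yl in place of 4-chlorophenyl on a carbonyl carbon.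

For the measured compounds named here, the steps that bear on this are the two exchanges on the same carbonyl carbon, a 6.8-fold higher number from compound 1 to compound 3 (0.83 log units; beyond the scatter) and a 3.1-fold higher number from compound 2 to compound 3 (0.49 log units; beyond the scatter); the remaining step, a 2.2-fold higher number from compound 1 to compound 2 (0.34 log units; beyond the scatter), exchanges a substituent on the aromatic carbon and is less relevant. All three measured variations keep a six-membered carbon ring on the carbonyl; none shows what a five-membered ring with two hetero atoms does there, so the direction is poorly anchored. Exchanges at this position have so far moved this assay by modest amounts only. Compound 4 is expected to stay near compound 3 or move further up, an estimated step of a 2.6-fold higher number from compound 3 to compound 4 (0.42 log units; beyond the scatter). For compound 4 the estimate in this assay is 1500 nM, with a range of 450 nM to 5000 nM.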

Compound 4, half-maximal effective concentration: 24 nM
Compound 4: the middle estimate sits 63-fold (1.80 log units) above what was measured, and the stated range ends above it.
By their numbers in this assay, from the lowest: compound 4; then compound 1; then compound 2; then compound 3.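

In this assay, exchanges on this carbonyl carbon reach further than the three phenyl compounds showed, and the direction reverses: 1,3-oxazol-5-yl in place of 4-chlorophenyl gives a 24-fold lower number from compound 3 to compound 4 (1.38 log units; beyond the scatter), a large step. The same ring also improves on both other aryl groups, with a 7.7-fold lower number from compound 2 to compound 4 (0.89 log units; beyond the scatter) and a 3.5-fold lower number from compound 1 to compound 4 (0.54 log units; beyond the scatter), so a six-membered carbon ring on the carbonyl is not required and compound 4 has the lowest number of the four. Nothing shown here indicates which feature of the entering ring accounts for this.

Going by these compounds, it remains open whether the ring size or the hetero atoms carry the change; a furan or a thiophene at the same carbonyl would separate the two. Also open, on these data alone, is how an amine or a carboxylic acid on the 1,3-oxazol-5-yl ring would read in this assay.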